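Moving the chlorine on the hydrazone aryl ring of compound 3

The source may hold more compounds than are shown below. What is called first, only, known or untested is meant among the compounds shown, and "the series" means these compounds.

Three semicarbazones sharing one core have been tested in a functional assay on the whole organism (strain Swiss albino) with Mus musculus as the target, with a stated time of 0.5 h; a higher number here means that more compound is needed for the effect, a lower number that less compound is needed. Compound 1 `O=C(N/N=C/c1ccc(Cl)cc1Cl)Nc1cccc2ccccc12` gives 300 mg/kg, compound 2 `COc1cccc(/C=N/NC(=O)Nc2cccc3ccccc23)c1` gives 100 mg/kg, and compound 3 `O=C(N/N=C/c1ccc(Cl)cc1)Nc1cccc2ccccc12` gives 300 mg/kg. Compound 3 thus stands level with compound 1, the two together at the highest numbers seen, while compound 2 sits below them by a 3.0-fold higher number from compound 2 to compound 3 (0.48 log units; beyond the scatter).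

Compound 4 `O=C(N/N=C/c1ccccc1Cl)Nc1cccc2ccccc12` differs from compound 3 by 2-chlorophenyl in place of 4-chlorophenyl on a carbon with a double bond to nitrogen. Among the measured steps, only the change from compound 1 to compound 3, which removed a chloro group from an aromatic carbon, touches chlorine substitution at all, and it gave no change at the digits printed from compound 1 to compound 3 (within the scatter). The two steps involving the methoxyphenyl group, a 3.0-fold lower number from compound 1 to compound 2 (0.48 log units; beyond the scatter) and a 3.0-fold higher number from compound 2 to compound 3 (0.48 log units; beyond the scatter), concern a different group and say nothing about where a chlorine sits. Among the measured compounds shown here, no measured pair moves a chlorine from one ring position to another.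

On this basis compound 4 is expected to show no change at the digits printed from compound 3 to compound 4 (within the scatter) in this assay, that is, no change beyond the scatter. The estimate for compound 4 is 300 mg/kg, with a likely range from 100 mg/kg to 1000 mg/kg.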

Compound 4, minimum effective dose: 300 mg/kg
Beside the measured number, compound 4's estimate shows no gap at the digits printed, and the stated range covers the measured number.
By their numbers in this assay, from the lowest: compound 2; then compounds 1, 3 and 4 (each within the scatter of the next).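

In this assay, putting 2-chlorophenyl in place of 4-chlorophenyl on the carbon with a double bond to nitrogen gives no change at the digits printed from compound 3 to compound 4 (within the scatter), and this is the only pair shown that compares two chlorine positions directly. Removing the other chlorine from the 2,4-dichlorophenyl group also gives no change at the digits printed from compound 1 to compound 4 (within the scatter), so the minimum effective dose stays level whichever of the two chlorines remains. The 3-methoxyphenyl compound remains apart from this chlorinated set, with a 3.0-fold higher number from compound 2 to compound 4 (0.48 log units; beyond the scatter).

No measurement here explains why these chlorine changes leave the number level. On these data alone, it also remains open whether an amine or a carboxylic acid in place of the chlorine would leave the minimum effective dose unchanged or move it as the 3-methoxyphenyl group does.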